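Bare core without the piperazinylbutyl chain: expected cytotoxicity

The compounds below may be only part of what the source reports. "The series", "measured", "known", "first", "only" and "open" are said of these compounds alone.

Within the data shown here, compound 1 `CN1CCN(CCCCn2c3c(c4ccccc42)C(=O)c2c[n+]([O-])c4ccccc4c2C3=O)CC1` holds the lower of the two numbers measured so far: in a toxicity assay on L02 cells (Homo sapiens) for cytotoxicity, read by MTT assay, with a stated time of 72 h (a lower number here means a stronger inhibitor, a higher number a weaker inhibitor), compound 1 gives 80 nM, while compound 2 `CC1(C)O[C@@H](CO)[C@H](Cn2cc(Cn3c4c(c5ccccc53)C(=O)c3c[n+]([O-])c5ccccc5c3C4=O)nn2)O1` gives 500 nM, a gap beyond the scatter. Compound 3 `O=C1c2c[n+]([O-])c3ccccc3c2C(=O)c2[nH]c3ccccc3c21` is the unsubstituted parent of the shared core and differs from compound 1 by hydrogen in place of 4-(4-methylpiperazin-1-yl)butyl on an aromatic nitrogen. Among the measured compounds shown here, no step between measured compounds covers this change, so the outlook rests on expectation alone. Loss of the whole chain is expected to weaken inhibition, with the step estimated as a 5.0-fold higher number from compound 1 to compound 3 (0.70 log units; beyond the scatter). For compound 3 the expected value is 400 nM, in a range from 100 nM to 2000 nM.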

Compound 3, half-maximal inhibitory concentration: 400 nM
Compound 3: the middle estimate sits on the measured number at the digits printed, within the range that was stated.
By their numbers in this assay, from the lowest: compound 1; then compounds 3 and 2 (each within the scatter of the next).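

In this assay, among these compounds, hydrogen in place of 4-(4-methylpiperazin-1-yl)butyl on the aromatic nitrogen gives a 5.0-fold higher number from compound 1 to compound 3 (0.70 log units; beyond the scatter) and provides the first direct reading of this position. The step belongs to the chain as a whole, not to the butyl part or the piperazine ring separately. No measurement at hand explains the step.

As far as these compounds go, whether a methyl group alone on this nitrogen would stay nearer to compound 1 or to compound 3 remains open. So does the effect of a morpholine in place of the 4-methylpiperazine at the end of the butyl chain.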